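From a Pyrrolidine Ring to an Open Chain

The source may hold more compounds than are shown below. What is called first, only, known or untested is meant among the compounds shown, and "the series" means these compounds.

Measured so far in a physicochemical assay for solubility, read by HPLC, in phosphate buffer, at pH 6.5; on this read-out lower numbers stand for lower solubility and higher numbers for higher solubility:
- compound 1 `COC(=O)C1=C(C)NC(c2nccs2)=NC1(C)c1ccc(F)cc1`: 22 ug/mL
- compound 2 `COC(=O)C1=C(CN2CCOCC2=O)NC(c2nccs2)=NC1(C)c1ccc(F)cc1`: 440 ug/mL
- compound 3 `COC(=O)C1=C(CN2CCC(O)C2)NC(c2nccs2)=NC1(C)c1ccc(F)cc1`: 503 ug/mL

Compound 3 belongs to the upper pair of these three values. Its gap to the other member of that pair is small, a 1.1-fold higher number from compound 2 to compound 3 (0.06 log units; within the scatter), while its distance from the lowest value is large, a 23-fold higher number from compound 1 to compound 3 (1.36 log units; beyond the scatter).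

The next compound is compound 4 `COC(=O)C1=C(COC(C(=O)O)C(F)(F)F)NC(c2nccs2)=NC1(C)c1ccc(F)cc1`, not yet measured in this assay. The change is a group of 9 heavy atoms (3 carbon, 3 oxygen, 3 fluorine; no ring) in place of a group of 6 heavy atoms (4 carbon, 1 nitrogen, 1 oxygen; one five-membered non-aromatic ring with 1 hetero atom), on a saturated chain carbon bound to a double-bonded ring carbon. It replaces the 3-hydroxypyrrolidin-1-yl group on a saturated chain carbon bound to a double-bonded ring carbon.

Two measured steps at this same place bear on it, and both are large: a 20-fold higher number from compound 1 to compound 2 (1.30 log units; beyond the scatter) and a 23-fold higher number from compound 1 to compound 3 (1.36 log units; beyond the scatter). The two groups they introduce differ from each other, yet they end up level, a 1.1-fold higher number from compound 2 to compound 3 (0.06 log units; within the scatter). Among the compounds with values here, no measured compound carries the entering group, so this evidence is indirect. Even so, it suggests that compound 4 will stay near the upper pair, and no step beyond the scatter is expected: a 1.4-fold higher number from compound 3 to compound 4 (0.14 log units; within the scatter). For compound 4 the estimated value is 700 ug/mL, with an expected range from 200 ug/mL to 2000 ug/mL.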

Compound 4, solubility: > 649 ug/mL
Compound 4 ended at the assay's limit; the forecaster's own chance of this, stated with the estimate: 15%; the middle value is on the limit's open side.
By their numbers in this assay, from the lowest: compound 1; then compounds 2 and 3 (each within the scatter of the next). At a limit, above all of these: compound 4.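

In this assay compound 4 stands at a limit of the assay and not at a number: the limit of > 649 ug/mL in this assay, at which 1 of the 4 values shown sits.

Within the data shown here, this is the first group at this place, on a saturated chain carbon bound to a double-bonded ring carbon, that has no ring and no nitrogen among its atoms, yet the step from hydrogen stays large, an at least 29-fold higher number from compound 1 to compound 4 (1.46 log units; beyond the scatter), so a large step at this place no longer goes only with the two nitrogen-bearing ring groups. Against those two groups only floors can be read, an at least 1.2-fold higher number from compound 3 to compound 4 (0.11 log units; that floor lies within the scatter) and an at least 1.4-fold higher number from compound 2 to compound 4 (0.16 log units; that floor lies within the scatter), and as both floors lie within the scatter, the result does not settle whether the open chain truly exceeds them.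

The compounds shown leave open how far compound 4 lies past its limit, and which part of the entering group goes with the step, the trifluoromethyl or the carboxylic acid. An open chain with the carboxylic acid but no trifluoromethyl, the methyl ester of compound 4, or an open-chain amine at the same place would each bear on that question.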